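The source may report more compounds than this note shows. Statements on the series, on what has been measured and on what is new or still open speak of the compounds shown alone.

Measured so far:
Compound 1 `CC(=O)N1CCN(c2ccc(Nc3ncc(C(F)(F)F)c(N4Cc5cccc(N(C)S(C)(=O)=O)c5C4)n3)cc2)CC1`: 22100 nM
Compound 2 `COc1ccc(C(F)(F)F)cc1Nc1ncc(C(F)(F)F)c(N2Cc3cccc(N(C)S(C)(=O)=O)c3C2)n1`: > 30000 nM

Among the measured compounds shown here, in a functional assay on U-87MG ATCC cells for antiproliferative activity against U-87 MG (Homo sapiens), read by spectrophotometry, with a stated time of 2 days (on this read-out higher numbers stand for weaker inhibition of growth and lower numbers for stronger inhibition of growth), compound 1 gives 22100 nM, the only actual number so far. Compound 2 is recorded as > 30000 nM, which is a limit of this assay and not a number.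

The next compound is compound 3 `COc1cc(N2CCN(C(C)=O)CC2)ccc1Nc1ncc(C(F)(F)F)c(N2Cc3cccc(N(C)S(C)(=O)=O)c3C2)n1`. It keeps the core of compound 1 and makes one change, methoxy in place of hydrogen on an aromatic carbon, ortho to a large group and meta to a 4-acetylpiperazin-1-yl group. For the measured compounds named here, no measured pair isolates this change, so no shift beyond the scatter is expected in this assay, and a direction cannot be assigned with confidence. The estimated step of a 1.2-fold lower number from compound 1 to compound 3 (0.09 log units; within the scatter) is therefore small. For compound 3 the expected value is 18000 nM, with an estimated range from 6000 nM to 30000 nM.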

Compound 3, concentration for 50% growth inhibition: 4700 nM
Compound 3: the middle estimate sits 3.8-fold (0.58 log units) above what was measured, outside the stated range (below it).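

In this assay, methoxy in place of hydrogen on an aromatic carbon, ortho to a large group and meta to a 4-acetylpiperazin-1-yl group, gives a 4.7-fold lower number from compound 1 to compound 3 (0.67 log units; beyond the scatter). Among the compounds shown here, this is the first pair that differs in one place, and it shows that this position responds to substitution, with the change going towards stronger inhibition of growth and lying beyond the usual scatter. Compound 2 is a limit of the assay and not a number, and it gives no step: the limit of > 30000 nM in this assay, at which 1 of the 3 values shown sits.

On these data alone, only hydrogen and methoxy are compared at this position, and whether the step is specific to methoxy remains open; fluorine, ethoxy or a dimethylamino group there would test this. Also open, as far as these compounds go, is whether the step holds when another group replaces the 4-acetylpiperazin-1-yl group.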